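The source may hold more compounds than are shown below. What is called first, only, known or untested is meant among the compounds shown, and "the series" means these compounds.

Measured compounds:
compound 1 `O=C(/C=C/c1ccc2c(c1)B(O)OC2)c1ccc(I)cc1` — > 100000 nM
compound 2 `CCOC(=O)c1ccc(C(=O)/C=C/c2ccc3c(c2)B(O)OC3)cc1` — 47200 nM

Compound 1, in a toxicity assay on WI-38 cells (Homo sapiens) for cytotoxicity, read by MTT assay, with a stated time of 48 h (on this read-out higher numbers stand for weaker inhibition and lower numbers for stronger inhibition), gives only > 100000 nM, which is a limit of the assay and not a number. Compound 2 gives 47200 nM in this assay. Within the data shown here, the one measured step, an at least 2.1-fold lower number from compound 1 to compound 2 (0.32 log units; beyond the scatter), is the only comparison available, and its size rests on the limit of > 100000 nM in this assay, at which 1 of the 2 values shown sits, rather than on two numbers.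

Compound 3 `O=C(/C=C/c1ccc2c(c1)B(O)OC2)c1ccccc1O` differs from compound 1 by 2-hydroxyphenyl in place of 4-iodophenyl on a carbonyl carbon. The measured step touches the same ring as the change to compound 3, but with a different entering group, so it tells the direction of a change at that place only loosely. Both measured values sit in the weak range of this assay, and nothing in the data points to a move to a strongly cytotoxic number. Compound 3 is therefore expected to remain weak, with an at least 1.6-fold lower number from compound 1 to compound 3 (0.22 log units; that floor lies within the scatter) as the expected step. The estimate for compound 3 in this assay is 60000 nM, with a range from 20000 nM to 150000 nM; a limit rather than a number is also quite possible.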

Compound 3, half-maximal inhibitory concentration: > 100000 nM
Compound 3: a limit, no number; the forecaster's own chance of this, stated with the estimate: 40%; at least 1.6-fold (0.22 log units) between middle value and limit.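

In this assay compound 3 gives > 100000 nM, a limit and not a number. Compound 1 also stands at a limit, so no step from it to compound 3 can be read: the limit of > 100000 nM in this assay, at which 2 of the 3 values shown sit.

The compounds shown leave open whether 2-hydroxyphenyl in place of 4-iodophenyl on a carbonyl carbon changes the cytotoxicity number at all.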